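This account rests on a few compounds, and the source may have more. Where it says the series, first, only, none or still open, it means among the compounds named here.

Measured compounds:
compound 1 `O=C(O)c1cc(-c2csnn2)ccc1O`, > 200 mg/kg
compound 2 `O=C(O)c1ccc(-c2cscn2)cc1O`, 70 mg/kg

The account follows compound 1 and compound 2 in a functional assay on the whole organism for inhibition, with Rattus norvegicus as the target, read by paw edema; a higher number here means that more compound is needed for the effect, a lower number that less compound is needed. Compound 1 gives > 200 mg/kg, which is a limit of the assay rather than a number (the limit of > 200 mg/kg in this assay, at which 1 of the 2 values shown sits). Compound 2 gives 70 mg/kg in this assay, a measured value. Among the measured compounds shown here, no step between two measured compounds that differ in one place is available here.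

Compound 3 `O=C(O)c1cc(-n2ccnn2)ccc1O` is not yet measured. It differs from compound 1 in one place: 1H-1,2,3-triazol-1-yl in place of 1,2,3-thiadiazol-4-yl on an aromatic carbon. For the measured compounds named here, since compound 1 stands only at a limit, no measured step anchors the change, and the expected step of a number no higher from compound 1 to compound 3 (the limit leaves the size open) is small, with no direction claimed beyond the scatter. Compound 3 is expected to give about 200 mg/kg in this assay, within a range from 80 mg/kg to 400 mg/kg, with a real chance that only a limit is again reported.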

Compound 3, dose for half-maximal effect: 150 mg/kg
For compound 3 the middle estimate is 1.3-fold (0.12 log units) above the measured one; low and high end bracket the measured number.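

In this assay, putting 1H-1,2,3-triazol-1-yl in place of 1,2,3-thiadiazol-4-yl on the aromatic carbon meta to the carboxy group and para to the hydroxy group gives an at least 1.3-fold lower number from compound 1 to compound 3 (0.12 log units; that floor lies within the scatter). Among the compounds shown here, compound 3, at 150 mg/kg, thus provides the first measured number for a compound with a five-membered aromatic ring at this position of the shared core. The value for compound 1 is only a limit of the assay. The true size of the step cannot be read because compound 1 sits at that limit: the limit of > 200 mg/kg in this assay, at which 1 of the 3 values shown sits.

As far as these compounds go, what an amine or a longer alkyl chain would give on this aromatic carbon remains open. Compound 2 differs from compound 3 in more than one place, so it cannot show what this change alone does.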